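Swapping Benzyl for Cyclohexyl on the Ring Nitrogen

This account rests on a few compounds, and the source may have more. Where it says the series, first, only, none or still open, it means among the compounds named here.

Of the compounds shown here, three have so far been measured in an ADME assay on MDCK-II cells (Canis lupus familiaris) for cytotoxicity, read by MTT assay, with a stated time of 48 h; a lower number here means a stronger inhibitor, a higher number a weaker inhibitor. Compound 1 `O=[N+]([O-])c1ccc(CSc2nnnn2C2CCCCC2)c([N+](=O)[O-])c1` gives 17000 nM, and compound 3 `O=[N+]([O-])c1cc(C[Se]c2nnnn2Cc2ccccc2)cc([N+](=O)[O-])c1` gives 22000 nM; the two lie within the scatter of each other, so compound 3 merely holds the higher of the two numbers. Compound 2 `O=[N+]([O-])c1cc(CS(=O)(=O)c2nnnn2C2CCCCC2)cc([N+](=O)[O-])c1` returns only a limit in this assay, < 7500 nM. One of the three values sits at the limit of < 7500 nM in this assay, at which 1 of the 3 values shown sits. Compound 4 `O=[N+]([O-])c1cc(C[Se]c2nnnn2C2CCCCC2)cc([N+](=O)[O-])c1` differs from compound 3 by cyclohexyl in place of benzyl on an aromatic nitrogen. Going by the values given here, no measured pair isolates this change; compound 1, which carries cyclohexyl, gives 17000 nM close to compound 3. The step of a 1.1-fold lower number from compound 3 to compound 4 (0.04 log units; within the scatter) is therefore expected to stay within the scatter. Compound 4 is estimated at 20000 nM, somewhere between 8000 nM and 50000 nM.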

Compound 4, half-maximal inhibitory concentration: 19000 nM
Estimate against measurement, compound 4: 1.1-fold (0.02 log units) above; low and high end bracket the measured number.
By their numbers in this assay, from the lowest: compounds 1, 4 and 3 (each within the scatter of the next). At a limit, below all of these: compound 2.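

Going by these compounds alone, this pair is the first in this assay to isolate the group on the aromatic nitrogen, and cyclohexyl in place of benzyl gives a 1.2-fold lower number from compound 3 to compound 4 (0.06 log units; within the scatter). In this pair, the six-membered aromatic ring of benzyl gives way to the non-aromatic ring of cyclohexyl with no step beyond the scatter. Nothing measured here bears on a cause for this step. The compounds shown leave open how this position would respond to a group carrying an amine or a carboxylic acid, or to a longer chain. They also leave open whether the same swap would read alike with sulfur in place of selenium.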